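Adding a second fluoro to compound 2

The compounds below may be only part of what the source reports. "The series", "measured", "known", "first", "only" and "open" are said of these compounds alone.

In a physicochemical assay for solubility, at pH 7.4 (a higher number here means a more soluble compound, a lower number a less soluble compound), compound 2 `Cc1cc(NC(=O)Nc2ccc(F)cc2)c2ccccc2n1` gives 3700 nM and compound 1 `CCc1ccc(NC(=O)Nc2cc(C)nc3ccccc23)cc1` gives 3300 nM, the step being a 1.1-fold higher number from compound 1 to compound 2 (0.05 log units; within the scatter). Compound 3 `Cc1cc(NC(=O)Nc2ccc(O)cc2)c2ccccc2n1` gives 100 nM, far lower than either, so compound 2 stands in the upper pair of the three.

Compound 4 `Cc1cc(NC(=O)Nc2ccc(F)cc2F)c2ccccc2n1` differs by fluoro in place of hydrogen on an aromatic carbon, ortho to a large group, meta to a fluoro group. Among the compounds with values here, no measured step makes this exchange. The large steps both bring in hydroxy, as in a 37-fold lower number from compound 2 to compound 3 (1.57 log units; beyond the scatter) and a 33-fold lower number from compound 1 to compound 3 (1.52 log units; beyond the scatter), and compound 4 carries none. No step beyond the scatter is therefore expected in this assay. The estimated step is a 1.2-fold lower number from compound 2 to compound 4 (0.09 log units; within the scatter). Compound 4 is estimated at 3000 nM, with an expected range of 1200 nM to 6500 nM.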

Compound 4, solubility: 3000 nM
Compound 4: middle estimate and measured number agree at the digits printed, and the stated range covers the measured number.
By their numbers in this assay, from the lowest: compound 3; then compounds 4, 1 and 2 (each within the scatter of the next).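

In this assay, fluoro in place of hydrogen, ortho to a large group and meta to a fluoro group, gives a 1.2-fold lower number from compound 2 to compound 4 (0.09 log units; within the scatter) and stays within the scatter. This is the first step shown that adds a group to the aromatic ring instead of exchanging one, and a single fluoro at this position leaves the number close to that of compound 2. No available measurement explains this result.

Going by these compounds, it remains open whether an amine or a methoxy group at this position would also stay within the scatter of compound 2. On these data alone, the effect of hydroxy here is equally open, as its large step of a 37-fold lower number from compound 2 to compound 3 (1.57 log units; beyond the scatter) comes from replacing the fluoro group of compound 2.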